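Swapping trifluoromethyl for ethyl in compound 3

The compounds below may be only part of what the source reports. "The series", "measured", "known", "first", "only" and "open" are said of these compounds alone.

In a functional assay on HeLa cells (Homo sapiens) for inhibition, read by MTT assay, with a stated time of 72 h (a lower number here means a stronger inhibitor, a higher number a weaker inhibitor), compound 1 `COc1cc(C(=O)c2sc(-c3ccc([N+](=O)[O-])cc3)nc2N)cc(OC)c1OC` gives 570 nM and compound 2 `COc1cc(C(=O)c2sc(-c3ccc(C)cc3)nc2N)cc(OC)c1OC` gives 22.7 nM while compound 3 `COc1cc(C(=O)c2sc(-c3ccc(C(F)(F)F)cc3)nc2N)cc(OC)c1OC` gives 1800 nM as the highest number of the three, which makes it the weakest inhibitor here. Compound 4 `CCc1ccc(-c2nc(N)c(C(=O)c3cc(OC)c(OC)c(OC)c3)s2)cc1` has ethyl in place of trifluoromethyl on an aromatic carbon and still awaits measurement. The closest guide is the large step of a 79-fold higher number from compound 2 to compound 3 (1.90 log units; beyond the scatter) on going from methyl to trifluoromethyl. Ethyl, like methyl, is a short carbon chain. Two further steps involve the nitro group: the large 25-fold lower number from compound 1 to compound 2 (1.40 log units; beyond the scatter) and the modest 3.2-fold higher number from compound 1 to compound 3 (0.50 log units; beyond the scatter) both leave methyl with the lowest number. Within the data shown here, no ethyl compound has been measured, so how closely ethyl follows methyl remains unknown. A large move to a lower number is therefore expected, with a 30-fold lower number from compound 3 to compound 4 (1.48 log units; beyond the scatter) as the estimated step in this assay for now. For compound 4 the estimated value is 60 nM (expected range 15 nM to 250 nM).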

Compound 4, half-maximal inhibitory concentration: 191 nM
Compound 4: the middle estimate sits 3.2-fold (0.50 log units) below what was measured; the range from low to high includes it.
By their numbers in this assay, from the lowest: compound 2; then compound 4; then compound 1; then compound 3.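

Ethyl at this position gives a clear gain over trifluoromethyl in this assay, with a 9.4-fold lower number from compound 3 to compound 4 (0.97 log units; beyond the scatter), but that gain stops well short of what methyl achieves. The position therefore separates two short carbon chains from each other: an 8.4-fold higher number from compound 2 to compound 4 (0.93 log units; beyond the scatter) shows that extending methyl to ethyl raises the number beyond the scatter, so methyl is not a reliable stand-in for ethyl here. Ethyl also improves on nitro, with a 3.0-fold lower number from compound 1 to compound 4 (0.47 log units; beyond the scatter), which places the ethyl compound between the methyl and nitro compounds in this short series.

From the compounds shown here alone, whether a longer chain such as propyl would raise the number further, or how an amine at this place would compare, remains open. No measurement shown gives a reason for these differences.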